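The source may report more compounds than this note shows. Statements on the series, on what has been measured and on what is new or still open speak of the compounds shown alone.

Compound 1 `Cc1ccc(NC(=O)Nc2cccc(CNc3nccnc3Cl)c2)cc1C` gives 9870 nM in a functional assay on MGC-803 cells (Homo sapiens) for antiproliferative activity, read by MTT assay, with a stated time of 48 h; on this read-out higher numbers stand for weaker inhibition and lower numbers for stronger inhibition. Compound 2 `Cc1ccc(NC(=O)Nc2cccc(CNc3nccnc3Cl)c2)cc1Cl` gives 17500 nM. For compound 3 `O=C(Nc1cccc(CNc2nccnc2Cl)c1)NC1CCCCC1` this assay reports only a limit, > 40000 nM.

Among the two numbers shown, compound 1 stands lowest, with compound 2 nearest; the step of a 1.8-fold higher number from compound 1 to compound 2 (0.25 log units; within the scatter) lies within the scatter, so the two cannot be ranked. The step of an at least 4.0-fold higher number from compound 1 to compound 3 (0.60 log units; beyond the scatter) and the step of an at least 2.2-fold higher number from compound 2 to compound 3 (0.35 log units; beyond the scatter) both run toward weaker inhibition, and only a limit is known for compound 3 (the limit of > 40000 nM in this assay, at which 1 of the 3 values shown sits).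

Compound 4 `O=C(Nc1ccc(Cl)cc1)Nc1cccc(CNc2nccnc2Cl)c1` differs from compound 1 in one place: 4-chlorophenyl in place of 3,4-dimethylphenyl on an amide-type nitrogen. Within the data shown here, two measured steps bear on it. Exchanging methyl for chloro on the aromatic ring made no difference beyond the scatter, whereas removing the aromatic ring altogether, for cyclohexyl, cost at least a modest step. Compound 4 keeps the aromatic ring and only changes its substitution, so the expected step of a 1.3-fold higher number from compound 1 to compound 4 (0.12 log units; within the scatter) is small, with the number for compound 4 estimated at 13000 nM, between 5000 nM and 32000 nM.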

Compound 4, half-maximal inhibitory concentration: 4980 nM
The estimate for compound 4 lay 2.6-fold (0.42 log units) above the measured number, outside the stated range (below it).
By their numbers in this assay, from the lowest: compounds 4, 1 and 2 (each within the scatter of the next, the first and the last beyond it). At a limit, above all of these: compound 3.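

On this amide-type nitrogen, 4-chlorophenyl cannot be told apart from 3,4-dimethylphenyl in this assay, with a 2.0-fold lower number from compound 1 to compound 4 (0.30 log units; within the scatter) as the step between them. Among these compounds, the same compound does separate from a ring bearing two different groups, with a 3.5-fold lower number from compound 2 to compound 4 (0.55 log units; beyond the scatter) as the first step beyond the scatter between two aromatic groups here, so the substitution on this phenyl ring can change the number even though compounds 1 and 2 could not be ranked. Against cyclohexyl, an at least 8.0-fold lower number from compound 3 to compound 4 (0.90 log units; beyond the scatter) is the widest step yet, and it is only a minimum, since compound 3 is known by a limit alone: the limit of > 40000 nM in this assay, at which 1 of the 4 values shown sits.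

The compounds shown leave open whether a plain phenyl, or a phenyl carrying methoxy or an amine, would hold this level. They also leave open whether moving the chlorine to another ring carbon would change the number.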